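A few compounds are considered here, and "the series" means these few. Any claim that something is new, unique, unknown or untested is made for them only; others in the source may bear on it.

Compound 1 `COc1cc(-c2nnc(SCc3ccccc3Cl)n2N2C(=O)c3ccccc3C2=O)cc(OC)c1OC` and compound 2 `COc1cc(-c2nnc(SCc3ccccc3)n2N2C(=O)c3ccccc3C2=O)cc(OC)c1OC` share one core and differ only in a single group on the outer aromatic ring. In a functional assay on PC-3M cells (Homo sapiens) for cytotoxicity, read by MTT assay, with a stated time of 48 h (a higher number here means a weaker inhibitor, a lower number a stronger inhibitor), compound 1 gives > 200000 nM, which is a limit of the assay rather than a number. In this assay compound 2 likewise gives > 200000 nM, again a limit and not a number. The step from compound 1 to compound 2 a step that the two limits leave unreadable from compound 1 to compound 2 therefore cannot be read, because both results sit at the limit of > 200000 nM in this assay, at which 2 of the 2 values shown sit. Compound 2 thus stands at the limit of this assay, with no measured number of its own.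

Compound 3 `COc1cc(-c2nnc(SCC(=O)c3ccccc3)n2N2C(=O)c3ccccc3C2=O)cc(OC)c1OC` differs from compound 2 by the change benzoyl in place of phenyl on a saturated chain carbon bound to a sulfur. The only measured step is the unreadable one between compound 1 and compound 2, so nothing about the size or direction of this new step can be inferred from the numbers shown. For compound 3 the expected result in this assay is 250000 nM, within a range of 50000 nM to 1000000 nM. The step from compound 2 to compound 3 is estimated as a step that the limit leaves unreadable from compound 2 to compound 3, most likely again a limit.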

Compound 3, half-maximal inhibitory concentration: > 200000 nM
Compound 3 gave a limit, no number; the forecaster's own chance of this, stated with the estimate: 70%; the middle value does not contradict the limit.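

Compound 3 gives a limit and not a number in this assay, so its steps from compound 1 and compound 2 cannot be read, because all three results sit at the same limit: the limit of > 200000 nM in this assay, at which 3 of the 3 values shown sit.

The compounds shown leave open whether any group on this sulfur-bound chain gives a measurable number in this assay, and how large these changes are.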